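From naphthalen-2-yl to heptyl on a shared core

A few compounds are considered here, and "the series" means these few. Any claim that something is new, unique, unknown or untested is made for them only; others in the source may bear on it.

Measured so far in a functional assay on A549 cells (Homo sapiens) for inhibition, read by MTT assay, with a stated time of 48 h; on this read-out higher numbers stand for weaker inhibition and lower numbers for stronger inhibition:
Compound 1 `COc1cccc(C(c2c[nH]c3ccc(Br)cc23)c2c[nH]c3ccc(Br)cc23)c1OC` gives 100000 nM
Compound 2 `CN(C)c1ccc(C(c2c[nH]c3ccc(Br)cc23)c2c[nH]c3ccc(Br)cc23)cc1` gives 25000 nM
Compound 3 `Brc1ccc2[nH]cc(C(c3ccc4ccccc4c3)c3c[nH]c4ccc(Br)cc34)c2c1` gives 8500 nM

Compound 3 has the lowest number of the three, which makes it the strongest inhibitor of this small set. The next compound, compound 4 `CCCCCCCC(c1c[nH]c2ccc(Br)cc12)c1c[nH]c2ccc(Br)cc12`, has not been measured yet. It differs from compound 3 by one change: heptyl in place of naphthalen-2-yl on a saturated chain carbon bound to two aromatic carbons, with heptyl in place of naphthalen-2-yl on a saturated chain carbon bound to two aromatic carbons.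

Two measured steps at this same place bear on it. The large one is a 12-fold lower number from compound 1 to compound 3 (1.07 log units; beyond the scatter) and the modest one is a 2.9-fold lower number from compound 2 to compound 3 (0.47 log units; beyond the scatter). Both end on naphthalen-2-yl, and neither shows what an open chain does there. Losing the group with the lowest number therefore points to a modest move towards a higher number in this assay, though with wide uncertainty. The expected change is a 2.1-fold higher number from compound 3 to compound 4 (0.33 log units; beyond the scatter). For compound 4 the estimate is 18000 nM, with an expected range from 6000 nM to 60000 nM.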

Compound 4, half-maximal inhibitory concentration: 3500 nM
The estimate for compound 4 lay 5.1-fold (0.71 log units) above the measured number; the whole stated range lies above it.
By their numbers in this assay, from the lowest: compound 4; then compound 3; then compound 2; then compound 1.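

In this assay an aromatic ring is not needed on the saturated chain carbon bound to two aromatic carbons: heptyl, which has no ring, gives a 2.4-fold lower number from compound 3 to compound 4 (0.39 log units; beyond the scatter) and the other two compounds show larger steps, a 7.1-fold lower number from compound 2 to compound 4 (0.85 log units; beyond the scatter) and a 29-fold lower number from compound 1 to compound 4 (1.46 log units; beyond the scatter) for the same kind of swap. Going by these compounds alone, compound 4 is therefore the strongest inhibitor of the four, something the earlier compounds could not reveal, since all of them carry aromatic rings at this place. Nothing measured here explains why the open chain gives the lowest number.

Heptyl is the only open chain shown, so it remains unclear whether a shorter chain such as butyl or a longer one such as decyl would do as well. Also unknown is how an amine or a carboxylic acid at the end of the heptyl chain would change the number.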